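Pyridin-2-yl in place of 4-methylcyclohexyl: working notes

The source may report more compounds than this note shows. Statements on the series, on what has been measured and on what is new or still open speak of the compounds shown alone.

Values in an ADME assay on MRC5 cells (Homo sapiens) for inhibition, with a stated time of 72 h; on this read-out higher numbers stand for an effect only at larger amounts of compound and lower numbers for an effect already at smaller amounts:
compound 1 `COc1cccc(OC)c1C(=O)Nc1c[nH]nc1C(=O)NC1CC2CCC1C2`: > 50000 nM
compound 2 `COc1cccc(OC)c1C(=O)Nc1c[nH]nc1C(=O)NCc1ncccc1C`: > 50000 nM
compound 3 `COc1cccc(OC)c1C(=O)Nc1c[nH]nc1C(=O)NC1CCC(C)CC1`: 45000 nM
compound 4 `COc1cccc(OC)c1C(=O)Nc1c[nH]nc1C(=O)Nc1ccccn1`: not yet measured

The entries for compound 1 and compound 2 are limits, not numbers: both stand at the limit of > 50000 nM in this assay, at which 2 of the 3 values shown sit. For the measured compounds named here, compound 3 gives 45000 nM, the only true number in the set.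

The change under review is pyridin-2-yl in place of 4-methylcyclohexyl on an amide-type nitrogen.

The closest measured change also removes or installs 4-methylcyclohexyl on that nitrogen, against (3-methylpyridin-2-yl)methyl in compound 2, and it reads an at least 1.1-fold lower number from compound 2 to compound 3 (0.04 log units; that floor lies within the scatter). The change from the other side reads an at least 1.1-fold lower number from compound 1 to compound 3 (0.04 log units; that floor lies within the scatter). The remaining pair gives a step that the two limits leave unreadable from compound 1 to compound 2. None of these steps shows a change beyond the scatter, so no clear step is expected in this assay, in either direction. The expected outcome is a 1.1-fold higher number from compound 3 to compound 4 (0.05 log units; within the scatter), and a further limit is quite possible. Compound 4 is estimated at 50000 nM, with an expected range of 20000 nM to 100000 nM.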

Compound 4, half-maximal effective concentration: > 50000 nM
Compound 4 gave a limit, no number; the forecaster's own chance of this, stated with the estimate: 60%; the middle value lies on the limit itself.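

In this assay, pyridin-2-yl in place of 4-methylcyclohexyl on an amide-type nitrogen gives an at least 1.1-fold higher number from compound 3 to compound 4 (0.04 log units; that floor lies within the scatter). For the compounds shown here, the series now includes pyridin-2-yl directly on that nitrogen, and this aromatic ring with a hetero atom gives no step beyond the scatter against the one compound with a true number. The steps among compound 1, compound 2 and compound 4 cannot be read, and the set remains dominated by one assay limit: the limit of > 50000 nM in this assay, at which 3 of the 4 values shown sit.

From the compounds shown here alone, whether any group on this nitrogen can give a step beyond the scatter in this assay remains open. Also open, going by these compounds, is how a carboxylic acid or an amine on the pyridine ring of compound 4, or a longer alkyl chain on that nitrogen, would read.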